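Nitro to cyano on the aryl ring: compound 4

The source may report more compounds than this note shows. Statements on the series, on what has been measured and on what is new or still open speak of the compounds shown alone.

Compound 1 `C=CC(=O)N1C(=O)CC(c2ccc([N+](=O)[O-])cc2)Sc2ccccc21`, compound 2 `C=CC(=O)N1C(=O)CC(c2ccc(OC)cc2)Sc2ccccc21` and compound 3 `C=CC(=O)N1C(=O)CC(c2ccccc2Cl)Sc2ccccc21` share one core. In a functional assay on Raji cells (Homo sapiens) for cytotoxicity, read by CCK-8 assay, with a stated time of 24 h (on this read-out lower numbers stand for stronger inhibition and higher numbers for weaker inhibition), compound 1 gives 34800 nM, compound 2 gives 43300 nM and compound 3 gives 50400 nM. Compound 1 holds the lowest of the three numbers, but both compound 2 and compound 3 sit within the scatter of it. The known steps, a 1.2-fold higher number from compound 1 to compound 2 (0.09 log units; within the scatter) and a 1.2-fold higher number from compound 2 to compound 3 (0.07 log units; within the scatter), are each within the scatter.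

Compound 4 `C=CC(=O)N1C(=O)CC(c2ccc(C#N)cc2)Sc2ccccc21` differs from compound 1 by cyano in place of nitro on an aromatic carbon. The step from compound 1 to compound 2 also replaced the nitro on that aromatic carbon and stayed within the scatter, so for compound 4 in this assay no step beyond the scatter is expected, estimated as a 1.1-fold higher number from compound 1 to compound 4 (0.04 log units; within the scatter). Compound 4 is expected at 38000 nM, within 17000 nM to 85000 nM.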

Compound 4, half-maximal inhibitory concentration: 84500 nM
Compound 4: middle estimate off by 2.2-fold (0.35 log units), on the low side; the measured number falls inside the stated range.
By their numbers in this assay, from the lowest: compounds 1, 2, 3 and 4 (each within the scatter of the next, the first and the last beyond it).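

Among the compounds shown here, at the aromatic carbon para to a large group, cyano in place of nitro gives the only step beyond the scatter in this assay, and a modest one: a 2.4-fold higher number from compound 1 to compound 4 (0.39 log units; beyond the scatter). The other two steps to this compound, a 2.0-fold higher number from compound 2 to compound 4 (0.29 log units; within the scatter) and a 1.7-fold higher number from compound 3 to compound 4 (0.22 log units; within the scatter), stay within the scatter, so the separation holds against compound 1 alone. The position is therefore not indifferent to what replaces nitro, although methoxy there stayed within the scatter in a 1.2-fold higher number from compound 1 to compound 2 (0.09 log units; within the scatter).

No data at hand account for the gap between cyano and nitro at this position. Going by these compounds, whether an amine or a carboxylic acid on this aromatic carbon would move the number, and in which direction, stays open.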